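Urea series, CDK8/Cyclin C binding: aryl methoxy position

The source may hold more compounds than are shown below. What is called first, only, known or untested is meant among the compounds shown, and "the series" means these compounds.

Measured so far:
compound 1, `CNc1nccc(N2CC[C@H](NC(=O)Nc3ccc(C)c(Cl)c3)C2)n1` — 18.4 nM
compound 2, `CNc1nccc(N2CC[C@H](NC(=O)Nc3ccc(OC)cc3)C2)n1` — 7160 nM

In an assay on a protein complex for displacement of a labelled ligand from CDK8/Cyclin C (Homo sapiens), read by TR-FRET, with a stated time of 1 h (on this read-out lower numbers stand for stronger inhibition and higher numbers for weaker inhibition), compound 2 has the highest number of the two measured compounds; its nearest neighbour is compound 1, and a 390-fold higher number from compound 1 to compound 2 (2.59 log units; beyond the scatter). Compound 3, `CNc1nccc(N2CC[C@H](NC(=O)Nc3cccc(OC)c3)C2)n1`, has not yet been measured. It differs from compound 2 by 3-methoxyphenyl in place of 4-methoxyphenyl on an amide-type nitrogen.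

Within the data shown here, no measured step concerns a change of this kind: the one recorded step, a 390-fold higher number from compound 1 to compound 2 (2.59 log units; beyond the scatter), exchanges a whole aryl group rather than shifting a methoxy group, so it fixes only the range of the series, from compound 1 to compound 2, and gives no direct size for the step from compound 2 to compound 3. The estimate for compound 3 is therefore kept wide; a moderate drop from the number of compound 2 is expected, a 3.6-fold lower number from compound 2 to compound 3 (0.55 log units; beyond the scatter). Compound 3 is expected to give about 2000 nM, in the range 400 nM to 10000 nM.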

Compound 3, half-maximal inhibitory concentration in the CDK8/Cyclin C assay: 3620 nM
For compound 3 the middle estimate is 1.8-fold (0.26 log units) below the measured one; low and high end bracket the measured number.
By their numbers in the CDK8/Cyclin C assay, from the lowest: compound 1; then compounds 3 and 2 (each within the scatter of the next).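

In the CDK8/Cyclin C assay the shift of the methoxy group gives a 2.0-fold lower number from compound 2 to compound 3 (0.30 log units; within the scatter) and so does not separate 3-methoxyphenyl from 4-methoxyphenyl, whereas a 200-fold higher number from compound 1 to compound 3 (2.29 log units; beyond the scatter) shows that 3-methoxyphenyl also remains far from 3-chloro-4-methylphenyl on this amide-type nitrogen. In a physicochemical assay for solubility, measured as kinetic solubility (a higher number here means a more soluble compound, a lower number a less soluble compound), compound 2 gives 92600 nM and compound 3 gives 116000 nM and these two values lie within the scatter of each other. Nothing at hand accounts for the gap between the methoxyphenyl compounds and the 3-chloro-4-methylphenyl compound.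

Still open, on these data alone, is whether that gap rests on the chlorine, the methyl group or the two together, which a 3-chlorophenyl or a 4-methylphenyl group on the same nitrogen would help to settle. Also open, as far as these compounds go, is how a larger ether such as ethoxy would read at either methoxy position.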